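From 4-nitrophenyl to 3-chlorophenyl at the assay limit

The source may report more compounds than this note shows. Statements on the series, on what has been measured and on what is new or still open speak of the compounds shown alone.

Results in a functional assay on NCI-H460 cells (Homo sapiens) for cytotoxicity, read by sulforhodamine B assay (a higher number here means that more compound is tolerated, a lower number that less compound is tolerated), each one a limit and not a number:
compound 1 `CC1=CC[C@@H]([C@@](C)(O)CCCC(C)(C)NC(=S)N/N=C\c2ccc(C)cc2)CC1`: > 100000 nM
compound 2 `CC1=CC[C@@H]([C@@](C)(O)CCCC(C)(C)NC(=S)N/N=C\c2ccc(N(C)C)cc2)CC1`: > 100000 nM
compound 3 `CC1=CC[C@@H]([C@@](C)(O)CCCC(C)(C)NC(=S)N/N=C\c2ccc([N+](=O)[O-])cc2)CC1`: > 100000 nM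

Compound 3 stands at > 100000 nM, which is a limit of this assay. All three compounds sit together at one mark: the limit of > 100000 nM in this assay, at which 3 of the 3 values shown sit.

Compound 4 `CC1=CC[C@@H]([C@@](C)(O)CCCC(C)(C)NC(=S)N/N=C\c2cccc(Cl)c2)CC1` carries 3-chlorophenyl in place of 4-nitrophenyl on a carbon with a double bond to nitrogen.

The measured steps that bear on this swap are a step that the two limits leave unreadable from compound 1 to compound 3, a step that the two limits leave unreadable from compound 2 to compound 3 and a step that the two limits leave unreadable from compound 1 to compound 2. None of them gives a size, so no step beyond the scatter is expected in this assay, and no direction either.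

The expected step is a number no higher from compound 3 to compound 4 (the limit leaves the size open).

For compound 4 the estimate is 100000 nM, with an expected range of 40000 nM to 150000 nM.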

Compound 4, concentration lethal to 50% of the cells: > 100000 nM
Compound 4: a limit, no number; the forecaster's own chance of this, stated with the estimate: 80%; the middle value lies on the limit itself.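

In this assay compound 4 gives > 100000 nM, again a limit and not a number. Among these compounds, no step among compound 1, compound 2, compound 3 and compound 4 can be read: the limit of > 100000 nM in this assay, at which 4 of the 4 values shown sit. On these data alone, whether these four compounds differ at all in this assay stays open.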